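Removing a Chloro Group: Expected Gain in Growth Inhibition

The source may report more compounds than this note shows. Statements on the series, on what has been measured and on what is new or still open speak of the compounds shown alone.

Measured so far in a functional assay on OVCAR-5 cells (Homo sapiens) for cytotoxicity, read by sulforhodamine B assay, with a stated time of 48 h; a lower number here means a stronger inhibitor of growth, a higher number a weaker inhibitor of growth:
compound 1 `ClCc1ccc(Cn2cnc3c(Cl)ncnc32)cc1` gives 9230 nM
compound 2 `ClCc1ccc(Cn2cnc3nc(Cl)nc(Cl)c32)cc1` gives 4260 nM
compound 3 `ClCc1ccc(Cn2cnc3c(Cl)nc(Cl)nc32)cc1` gives 34700 nM

Compound 2 shows the lowest of the three numbers, and its steps to compound 1 and to compound 3 both lie beyond the scatter. Compound 2 and compound 3 contain the same atoms joined differently; the difference between their cores is not broken down here. Compound 1 differs from compound 3 by hydrogen in place of chloro on an aromatic carbon, a change that brought a 3.8-fold lower number from compound 3 to compound 1 (0.58 log units; beyond the scatter). Compound 4 `ClCc1ccc(Cn2cnc3ncnc(Cl)c32)cc1` has not been measured in this assay; it differs from compound 2 by hydrogen in place of chloro on an aromatic carbon, the same change at the same place. Among the compounds with values here, the step from compound 2 to compound 4 is expected to be a 2.8-fold lower number from compound 2 to compound 4 (0.45 log units; beyond the scatter), because a 3.8-fold lower number from compound 3 to compound 1 (0.58 log units; beyond the scatter) was seen for the one earlier example of this change, though a single example gives only a loose footing. Compound 4 is therefore estimated at 1500 nM, expected to fall between 500 nM and 5000 nM.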

Compound 4, concentration for total growth inhibition: 19500 nM
Beside the measured number, compound 4's estimate is 13-fold (1.11 log units) below it; the whole stated range lies below it.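

In this assay, putting hydrogen in place of chloro on an aromatic carbon gave a 4.6-fold higher number from compound 2 to compound 4 (0.66 log units; beyond the scatter). The same change therefore moved the number in opposite directions on the two cores: the same change on two cores in this assay, a 3.8-fold lower number (0.58 log units; beyond the scatter) from compound 3 to compound 1 and a 4.6-fold higher number (0.66 log units; beyond the scatter) from compound 2 to compound 4, 17-fold (1.24 log units) apart, beyond the scatter of two such steps. This shows that in this series a step seen on one core cannot simply be copied to another, but two examples do not show why the cores differ or how a third core would respond.

Still open, as far as these compounds go, is how an amine or a methoxy group would behave at this carbon between two ring nitrogen atoms, on either core. Also open, from the compounds shown here alone, is what replacing the chloro group that remains in compound 4 would do.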